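Dichlorophenyl ethenyl in place of fluorophenyl ethenyl

A few compounds are considered here, and "the series" means these few. Any claim that something is new, unique, unknown or untested is made for them only; others in the source may bear on it.

Compound 2 `O=C(/C=C\c1ccccc1F)N1N=C(c2ccncc2)OC1c1c[nH]c2ccccc12` has been tested in an ADME assay on HeLa cells (Homo sapiens) for cytotoxicity, read by MTT assay, with a stated time of 72 h; on this read-out lower numbers stand for stronger inhibition of growth and higher numbers for weaker inhibition of growth. In this assay compound 2 gives > 30 ug/mL, which is a limit of the assay and not a number. Compound 1 `O=C(/C=C\c1ccccc1O)N1N=C(c2ccncc2)OC1c1c[nH]c2ccccc12` in this assay gives 26.8 ug/mL. Within the data shown here, the one measured step, an at least 1.1-fold higher number from compound 1 to compound 2 (0.04 log units; that floor lies within the scatter), rests on the limit of > 30 ug/mL in this assay, at which 1 of the 2 values shown sits, and is therefore open at its upper end. Compound 3 `O=C(/C=C/c1c(Cl)cccc1Cl)N1N=C(c2ccncc2)OC1c1c[nH]c2ccccc12` has not yet been measured in this assay. The change from compound 2 to compound 3 is 2-(2,6-dichlorophenyl)ethenyl in place of 2-(2-fluorophenyl)ethenyl on a carbonyl carbon. Among the measured compounds shown here, no measured step covers a change of this kind, so the only guide is that compound 1 and compound 2 both sit in the weak region of this assay with no step beyond the scatter between them. Compound 3 is therefore expected to remain in that region, with a step of a number no higher from compound 2 to compound 3 (the limit leaves the size open) that is not expected to exceed the scatter. Compound 3 is estimated at 30 ug/mL, within a range from 15 ug/mL to 60 ug/mL.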

Compound 3, concentration for 50% growth inhibition: > 30 ug/mL
Compound 3 gave a limit, no number; the forecaster's own chance of this, stated with the estimate: 55%; the middle value lies on the limit itself.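

In this assay compound 3 gives > 30 ug/mL, a limit of the assay and not a number. Going by these compounds, with 2-(2,6-dichlorophenyl)ethenyl on the carbonyl carbon, the comparison with the hydroxy compound gives an at least 1.1-fold higher number from compound 1 to compound 3 (0.04 log units; that floor lies within the scatter), and this step stays open at its upper end, so its true size is unknown. The step between compound 2 and compound 3 cannot be read, and a second group at this position now rests on the same limit: the limit of > 30 ug/mL in this assay, at which 2 of the 3 values shown sit.

On these data alone, whether any group at this position can bring the read-out clearly under the values shown remains open, as does any ranking of the compounds at the limit. A carboxylic acid or an amine on the phenyl ring, or a longer chain in place of the ethenyl link, would test this position further.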